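Ring size on the amide and mGlu5 modulation

The source may report more compounds than this note shows. Statements on the series, on what has been measured and on what is new or still open speak of the compounds shown alone.

Measured compounds:
compound 1 `CC1CC1C(=O)N1CCc2nc(C#Cc3ccccc3)sc2C1` gives 9.4 nM
compound 2 `O=C(C1CCC1)N1CCc2nc(C#Cc3ccccc3)sc2C1` gives > 10000 nM
compound 3 `CC1CCCC(C(=O)N2CCc3nc(C#Cc4ccccc4)sc3C2)C1` gives 100 nM

These three share one core and differ only in the ring attached to the carbonyl carbon, and all were tested in an assay on HEK293 cells for positive allosteric modulation of metabotropic glutamate receptor 5 (Homo sapiens), read by FLIPR, with a stated time of 1 h; on this read-out higher numbers stand for an effect only at larger amounts of compound and lower numbers for an effect already at smaller amounts. Compound 2 reaches only the limit of the assay (the limit of > 10000 nM in this assay, at which 1 of the 3 values shown sits), so for it no number is known. Among the two numbers that are known, compound 3 stands highest, and the step of an 11-fold higher number from compound 1 to compound 3 (1.03 log units; beyond the scatter) is large. The step of an at least 100-fold lower number from compound 2 to compound 3 (2.00 log units; beyond the scatter) is larger still, and an at least 1000-fold higher number from compound 1 to compound 2 (3.02 log units; beyond the scatter) shows how much a change of this ring can shift the read-out.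

Compound 4 `O=C(N1CCCC1)N1CCc2nc(C#Cc3ccccc3)sc2C1` carries pyrrolidin-1-yl in place of 3-methylcyclohexyl on a carbonyl carbon. Within the data shown here, the steps that bear on this change are an at least 100-fold lower number from compound 2 to compound 3 (2.00 log units; beyond the scatter) and an at least 1000-fold higher number from compound 1 to compound 2 (3.02 log units; beyond the scatter), both large, and both show that a small unbranched ring at this position sits far from the low numbers. Pyrrolidin-1-yl is a small five-membered ring without a methyl group, so a step upward from compound 3 is expected, though the pyrrolidin-1-yl ring holds a nitrogen atom that none of the measured rings has, so its size is uncertain.

Compound 4 is therefore expected to give 3000 nM, between 400 nM and 10000 nM, an expected step of a 30-fold higher number from compound 3 to compound 4 (1.48 log units; beyond the scatter).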

Compound 4, half-maximal effective concentration: 9.8 nM
Beside the measured number, compound 4's estimate is 310-fold (2.49 log units) above it, and the stated range ends above it.
By their numbers in this assay, from the lowest: compounds 1 and 4 (each within the scatter of the next); then compound 3. At a limit, above all of these: compound 2.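

In this assay, the change to pyrrolidin-1-yl gives a 10-fold lower number from compound 3 to compound 4 (1.01 log units; beyond the scatter), and the comparison with the methyl-bearing three-membered ring gives a 1.0-fold higher number from compound 1 to compound 4 (0.02 log units; within the scatter), so a small ring without a methyl group on this carbonyl carbon can match the 2-methylcyclopropyl of compound 1. Compound 2, with its cyclobutyl group, stands at a limit and not at a number, and the change from its ring to pyrrolidin-1-yl gives an at least 1000-fold lower number from compound 2 to compound 4 (3.00 log units; beyond the scatter), so the earlier impression that small unbranched rings sit far from the low numbers now rests on compound 2 alone, with compound 4 going against it. Ring size by itself therefore puts these four compounds in no simple order, since the five-membered ring of compound 4 and the three-membered ring of compound 1 stand together, while the four-membered and six-membered rings do not join them.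

The compounds shown leave open whether the ring nitrogen or the five-membered size goes with the low number of compound 4, a question that cyclopentyl on the same carbonyl carbon would address. They also leave open how far this extends to piperidin-1-yl, morpholin-4-yl or an open-chain dimethylamino group.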